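The source may report more compounds than this note shows. Statements on the series, on what has been measured and on what is new or still open speak of the compounds shown alone.

In a toxicity assay on the whole organism (J774 cells) for cytotoxicity, with Mus musculus as the target, read by MTT assay, with a stated time of 24 h, tested at 10 uM (a lower number here means a stronger effect, a higher number a weaker effect of the compound at the concentration tested), compound 1, `CCCCCCCCCO[C@@H]1[C@@H](N)[C@@H](OCC(O)CNCCCO)O[C@H](CN)[C@H]1OCCCCCCCCC`, gives 89.9%, the higher of the two numbers measured; compound 2, `NC[C@H]1O[C@H](O[C@H]2[C@H](O)[C@@H](O)[C@H](N)C[C@@H]2N)[C@H](N)[C@@H](OCc2ccc3ccccc3c2)[C@@H]1OCc1ccc2ccccc2c1`, gives 79.1% in this assay, a gap beyond the usual scatter. Compound 3, `C=CCO[C@H]1O[C@H](CN)[C@@H](OCCCCCCCCC)[C@H](OCCCCCCCCC)[C@H]1N`, is not yet measured. It differs from compound 1 in one place: vinyl in place of 1-hydroxy-2-((3-hydroxypropyl)amino)ethyl on a saturated chain carbon bound to an oxygen on a saturated carbon. Going by the values given here, no measured pair shows what this kind of change does. For compound 3 a modest downward step, a number 9.9 percentage points lower from compound 1 to compound 3 (within the scatter), is expected, close to the edge of the scatter. Compound 3 is estimated at 80% in this assay, with a range from 60% to 95%.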

Compound 3, a percentage reported as activity, at one concentration (the size of the read-out at that concentration, not a potency): 91.4%
For compound 3 the middle estimate is 11.4 percentage points below the measured one, and the stated range covers the measured number.
By their numbers in this assay, from the lowest: compound 2; then compounds 1 and 3 (each within the scatter of the next).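

In this assay, putting vinyl in place of 1-hydroxy-2-((3-hydroxypropyl)amino)ethyl on a saturated chain carbon bound to an oxygen on a saturated carbon gives a number 1.5 percentage points higher from compound 1 to compound 3 (within the scatter), so the two compounds cannot be told apart. At this position, a group of 8 heavy atoms with 3 hydrogen-bond donors and a group of 2 heavy atoms with none give readings within the scatter of each other. Nothing available accounts for this result. Going by these compounds, whether a carboxylic acid or a longer chain at this position would also stay within the scatter remains open.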